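Swapping the aryl ring for furan-2-yl on a thiosemicarbazone

The compounds below may be only part of what the source reports. "The series", "measured", "known", "first", "only" and "open" are said of these compounds alone.

Compound 2 `CC1=CC[C@H](C(C)(C)NC(=S)N/N=C/c2cccc(Cl)c2)CC1` gives 8000 nM in a functional assay on MCF7 cells (Homo sapiens) for inhibition, read by sulforhodamine B assay, with a stated time of 48 h (on this read-out higher numbers stand for weaker inhibition of growth and lower numbers for stronger inhibition of growth), the lower of the two numbers; compound 1 `COc1ccc(/C=N/NC(=S)NC(C)(C)[C@H]2CC=C(C)CC2)cc1` gives 31200 nM, and the step of a 3.9-fold lower number from compound 1 to compound 2 (0.59 log units; beyond the scatter) is the only one measured. Compound 3 `CC1=CC[C@H](C(C)(C)NC(=S)N/N=C/c2ccco2)CC1` carries furan-2-yl in place of 3-chlorophenyl on a carbon with a double bond to nitrogen. Among the compounds with values here, no measured step involves a five-membered ring, so the aryl swap from compound 1 to compound 2 is the sole guide to the size of ring exchanges here. A step of similar or smaller size toward a higher number is expected, a 1.9-fold higher number from compound 2 to compound 3 (0.27 log units; within the scatter). Compound 3 is therefore estimated at 15000 nM, within 5000 nM to 45000 nM.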

Compound 3, concentration for 50% growth inhibition: 9300 nM
Estimate against measurement, compound 3: 1.6-fold (0.21 log units) above; the range from low to high includes it.
By their numbers in this assay, from the lowest: compounds 2 and 3 (each within the scatter of the next); then compound 1.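

The step of a 1.2-fold higher number from compound 2 to compound 3 (0.07 log units; within the scatter) shows that, in this assay, furan-2-yl can take the place of 3-chlorophenyl on a carbon with a double bond to nitrogen with no change beyond the scatter. The step of a 3.4-fold lower number from compound 1 to compound 3 (0.53 log units; beyond the scatter) shows that a five-membered ring with a hetero atom and no chlorine also stands apart from the 4-methoxyphenyl compound in the same direction as 3-chlorophenyl. No evidence is available to explain this result. On these data alone, whether a pyridine ring, or a phenyl ring bearing an amine or a carboxylic acid, would give a lower number in this place remains open.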